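Compound 2 loses its hydroxy, gains a methyl

The compounds below may be only part of what the source reports. "The series", "measured", "known", "first", "only" and "open" are said of these compounds alone.

In a functional assay on KB cells (Homo sapiens) for inhibition, read by sulforhodamine B assay (on this read-out lower numbers stand for stronger inhibition of growth and higher numbers for weaker inhibition of growth), compound 1 `Oc1cccc2[nH]c(-c3ccc(-c4ccc(-c5ccc(F)cc5)cc4)cc3)nc12` gives 6920 nM while compound 2 `Oc1cccc2[nH]c(-c3ccc(-c4ccc(-c5ccc(OC(F)(F)F)cc5)cc4)cc3)nc12` gives 3310 nM and compound 3 `CN(C)c1ccc(-c2ccc(-c3ccc(-c4nc5c(O)cccc5[nH]4)cc3)cc2)cc1` gives 4200 nM here. Compound 2 stands at the low end of these numbers, with a 1.3-fold higher number from compound 2 to compound 3 (0.10 log units; within the scatter) separating it from its nearest neighbour. Compound 4 `Cc1ccc2[nH]c(-c3ccc(-c4ccc(-c5ccc(OC(F)(F)F)cc5)cc4)cc3)nc2c1` departs from compound 2 in one place (5-methyl-1H-benzimidazol-2-yl in place of 4-hydroxy-1H-benzimidazol-2-yl on an aromatic carbon). Going by the values given here, no measured step touches this part, so none tests the change directly. The group swaps measured elsewhere stayed small, the largest being a 2.1-fold lower number from compound 1 to compound 2 (0.32 log units; beyond the scatter) and, with only that to go on, no step beyond the scatter is expected in this assay for this change. The expected step is small (a 1.2-fold higher number from compound 2 to compound 4 (0.08 log units; within the scatter)). Compound 4 is estimated at 4000 nM (expected range 1300 nM to 12000 nM).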

Compound 4, concentration for 50% growth inhibition: 41200 nM
For compound 4 the middle estimate is 10-fold (1.01 log units) below the measured one; the measured number lies above the stated range.
By their numbers in this assay, from the lowest: compounds 2, 3 and 1 (each within the scatter of the next, the first and the last beyond it); then compound 4.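

Unlike the swaps among fluoro, trifluoromethoxy and dimethylamino, which changed the number little, replacing 4-hydroxy-1H-benzimidazol-2-yl with 5-methyl-1H-benzimidazol-2-yl makes a large difference in this assay, with a 12-fold higher number from compound 2 to compound 4 (1.10 log units; beyond the scatter). Growth inhibition is therefore far more sensitive to this part of the molecule than the earlier compounds suggested. Nothing available explains the weakening. The compounds shown cannot separate the loss of the hydroxy from the gain of the methyl, since both happen in one step. On these data alone, it also remains open how a methoxy or an amine in place of the hydroxy would behave.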